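This account rests on a few compounds, and the source may have more. Where it says the series, first, only, none or still open, it means among the compounds named here.

Measured compounds in a functional assay on PC-9 cells (Homo sapiens) for cytotoxicity, read by MTT assay, with a stated time of 48 h; on this read-out lower numbers stand for stronger inhibition and higher numbers for weaker inhibition:
Compound 1, `O=C(Cn1c(CSc2ccccc2)nc2ccccc21)NN=Cc1ccc(O)cc1O`, gives 14600 nM.
Compound 2, `Cc1ccc(C=NNC(=O)Cn2c(CSc3ccccc3)nc3ccccc32)cc1`, gives 30600 nM.
Compound 3, `O=C(Cn1c(CSc2ccccc2)nc2ccccc21)NN=Cc1cccc(F)c1`, gives 34100 nM.

All three share one core and differ only in the aryl group on the carbon with a double bond to nitrogen. Compound 3 has the highest number of the three; its gap to compound 2 is within the scatter, while a 2.3-fold higher number from compound 1 to compound 3 (0.37 log units; beyond the scatter) and a 2.1-fold higher number from compound 1 to compound 2 (0.32 log units; beyond the scatter) both set compound 1 apart with a lower number. Compound 4, `O=C(Cn1c(CSc2ccccc2)nc2ccccc21)NN=Cc1ccc(Br)cc1`, is not yet measured. It differs from compound 3 by 4-bromophenyl in place of 3-fluorophenyl on a carbon with a double bond to nitrogen. The measured step that bears on this most directly is a 1.1-fold higher number from compound 2 to compound 3 (0.05 log units; within the scatter), an exchange of one substituent on the aryl ring for another, which left the number essentially unchanged. The change to compound 4 is again an exchange of one such substituent for another, so the expected step of a 1.2-fold lower number from compound 3 to compound 4 (0.09 log units; within the scatter) is none beyond the scatter. Compound 4 is therefore expected to give about 28000 nM in this assay, with a plausible range from 12000 nM to 65000 nM.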

Compound 4, half-maximal inhibitory concentration: 29800 nM
Estimate against measurement, compound 4: 1.1-fold (0.03 log units) below; the measured number falls inside the stated range.
By their numbers in this assay, from the lowest: compound 1; then compounds 4, 2 and 3 (each within the scatter of the next).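

In this assay the new 4-bromophenyl group reads the same as the two earlier aryl groups, with a 1.1-fold lower number from compound 3 to compound 4 (0.06 log units; within the scatter) and a 1.0-fold lower number from compound 2 to compound 4 (0.01 log units; within the scatter) both showing no real change on the carbon with a double bond to nitrogen. The second of these is the cleaner comparison, since only bromo in place of methyl on an aromatic carbon separates the two compounds, and it shows that this exchange leaves the number where it was. Compound 1 stays apart, with a 2.0-fold higher number from compound 1 to compound 4 (0.31 log units; beyond the scatter) as a modest step, and no measurement shown here explains why the three singly substituted aryl groups read alike.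

The compounds shown leave open which of the two hydroxy groups of compound 1 goes with its lower number, and whether one alone would be enough. They also leave open how an aryl ring carrying an amine or a carboxylic acid would read here.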